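The compounds below may be only part of what the source reports. "The series", "measured", "known", "first", "only" and "open" are said of these compounds alone.

Working notes on the naphthyl series. The measured compounds are compound 1 `O=C1C=CC[C@H](c2cccc3ccccc23)O1`, compound 2 `Cc1ccc2ccccc2c1[C@H]1CC=CC(=O)O1` and compound 3 `C=CC[C@@H](OC(=O)C=C)c1cccc2ccccc12`; the unmeasured compound 4 `C=CC[C@@H](OC(=O)C=C)c1ccc(C)c2ccccc12` is the methylated partner of compound 3. In a functional assay on MCF7 cells (Homo sapiens) for cytotoxicity, read by MTT assay, with a stated time of 48 h (a lower number here means a stronger inhibitor, a higher number a weaker inhibitor), compound 1 gives 2600 nM. In this assay compound 2 gives 2600 nM. The step of no change at the digits printed from compound 1 to compound 2 (within the scatter) is the change (methyl in place of hydrogen on an aromatic carbon). For compound 3 this assay reports only a limit, > 50000 nM, which is the limit of > 50000 nM in this assay, at which 1 of the 3 values shown sits. How the core of compound 3 differs from the core of compound 1 is not broken down here.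

The change from compound 3 to compound 4 is methyl in place of hydrogen on an aromatic carbon. Within the data shown here, it is the same kind of change as the one from compound 1 to compound 2, not the same: in compound 2 the methyl sits ortho to a group of 7 heavy atoms, meta to a fused ring and para to a fused ring, whereas in compound 4 it sits ortho to a fused ring, meta to a fused ring and para to a group of 9 heavy atoms.

The expectation for compound 4 rests on the step of no change at the digits printed from compound 1 to compound 2 (within the scatter), which showed no change on methylation, and on the limit of compound 3 in this assay, so the step that the limit leaves unreadable from compound 3 to compound 4 is expected to be small. Compound 4 is therefore estimated at 70000 nM in this assay, most likely again reported only as a limit.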

Compound 4, half-maximal inhibitory concentration: 33100 nM
Compound 4: middle estimate off by 2.1-fold (0.33 log units), on the high side, and the stated range covers the measured number.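

In this assay compound 3 gives > 50000 nM, which is a limit of the assay and not a number. From the compounds shown here alone, measured against that limit, methyl in place of hydrogen on an aromatic carbon gives an at least 1.5-fold lower number from compound 3 to compound 4 (0.17 log units; that floor lies within the scatter), and this is only a floor, so the real size of the step stays unknown and may be larger. Whether the change carries from one core to the other is neither shown nor excluded, and the two pairs do not place the methyl alike, since in compound 4 it sits ortho to a fused ring, meta to a fused ring and para to a group of 9 heavy atoms: the same change on two cores in this assay, no change at the digits printed (within the scatter) from compound 1 to compound 2 and an at least 1.5-fold lower number (0.17 log units; that floor lies within the scatter) from compound 3 to compound 4; the limit leaves it open whether they differ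

Still open, going by these compounds, is whether a methyl elsewhere on the aromatic ring would behave in the same way on either core, and whether a different group at the same place, such as a methoxy group, an amine or a longer chain, would shift the number in this assay. Also open, on these data alone, is the size of this step on a core where both partners give a number rather than a limit.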